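Alkyne series: thiophene in place of tolyl at the alkyne

The source may report more compounds than this note shows. Statements on the series, on what has been measured and on what is new or still open speak of the compounds shown alone.

Compound 1 `Cc1cccc(C#Cc2ccc3c(n2)CCN(C)C3=O)c1` — 820 nM
Compound 2 `COc1cccc(C#Cc2ccc3c(n2)CCN(C)C3=O)c1` — 3660 nM
Compound 3 `Cc1cccc(C#Cc2ccc3c(n2)CCN(C(C)C)C3=O)c1` — 510 nM

In an assay on HEK293 cells for displacement of a labelled ligand from metabotropic glutamate receptor 5 (Homo sapiens), with a stated time of 2 h (on this read-out higher numbers stand for weaker inhibition and lower numbers for stronger inhibition), compound 3 carries the lowest of the three numbers; its gap to compound 1 lies within the scatter, while compound 2 stands at a clearly higher number than compound 3. Compound 4 `CC(C)N1CCc2nc(C#Cc3cccs3)ccc2C1=O` differs from compound 3 in one place: thiophen-2-yl in place of 3-methylphenyl on a triple-bonded carbon. Going by the values given here, no measured step exchanges the aryl ring itself. Among the compounds with values here, the nearest precedent is a 4.5-fold higher number from compound 1 to compound 2 (0.65 log units; beyond the scatter), a modest loss on altering a substituent of that ring, whereas a 1.6-fold lower number from compound 1 to compound 3 (0.21 log units; within the scatter) concerns the other end of the molecule. For compound 4 a small to modest weakening is therefore expected, a 2.0-fold higher number from compound 3 to compound 4 (0.29 log units; within the scatter), with wide uncertainty. Compound 4 is estimated at 1000 nM, within a range of 300 nM to 3500 nM.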

Compound 4, inhibition constant: 1930 nM
Compound 4: the middle estimate sits 1.9-fold (0.29 log units) below what was measured; low and high end bracket the measured number.
By their numbers in this assay, from the lowest: compounds 3 and 1 (each within the scatter of the next); then compounds 4 and 2 (each within the scatter of the next).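

Exchanging the aryl ring itself on the triple-bonded carbon registers in this assay: thiophen-2-yl in place of 3-methylphenyl gives a 3.8-fold higher number from compound 3 to compound 4 (0.58 log units; beyond the scatter). The number at this position therefore responds to the identity of the ring, as well as to the substituent change in a 4.5-fold higher number from compound 1 to compound 2 (0.65 log units; beyond the scatter). Nothing on hand explains this rise.

Open, going by these compounds, is whether a pyridin-2-yl ring or a fluorophenyl ring on the triple-bonded carbon would stay close to compound 3. Also open, on these data alone, is whether thiophen-2-yl gives a similar step with methyl on the amide-type nitrogen.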